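The compounds below may be only part of what the source reports. "The series", "measured", "known", "first", "only" and "open" are said of these compounds alone.

Compound 1 `CC(C)[C@H](NC(=O)COc1cccc2ccccc12)C(=O)N[C@@H](CC(=O)O)C(=O)CSc1nc2ccccc2[nH]1` was tested in a functional assay on Jurkat cells (Homo sapiens) for inhibition; a higher number here means a weaker inhibitor, a lower number a stronger inhibitor. In this assay compound 1 gives no number, only a limit, > 200000 nM. Compound 2 `CC(C)[C@H](NC(=O)COc1cccc2ccccc12)C(=O)N[C@@H](CC(=O)O)C(=O)COc1cc(C(F)(F)F)ncn1` likewise reaches only a limit, > 200000 nM. Compound 3 `CC(C)[C@H](NC(=O)COc1cccc2ccccc12)C(=O)N[C@@H](CC(=O)O)C(=O)COc1cc2ccccc2cn1` also stops at a limit, > 200000 nM. All three values rest at the limit of > 200000 nM in this assay, at which 3 of the 3 values shown sit, so the steps a step that the two limits leave unreadable from compound 1 to compound 2 and a step that the two limits leave unreadable from compound 1 to compound 3 cannot be read in size or direction. Compound 4 `CC(C)[C@H](NC(=O)COc1cccc2ccccc12)C(=O)N[C@@H](CC(=O)O)C(=O)COc1nccc2ccccc12` carries (isoquinolin-1-yl)oxy in place of (1H-benzimidazol-2-yl)sulfanyl on a saturated chain carbon bound to a carbonyl carbon. Compound 3 bears the related (isoquinolin-3-yl)oxy group and, as noted, sits at its limit. With every measured compound at the limit, the step of a number no higher from compound 1 to compound 4 (the limit leaves the size open) is expected to show no readable change. Compound 4 is therefore estimated at 200000 nM, between 50000 nM and 1000000 nM, most likely once more as a limit.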

Compound 4, half-maximal inhibitory concentration: 106000 nM
The estimate for compound 4 lay 1.9-fold (0.28 log units) above the measured number; low and high end bracket the measured number.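

In this assay, among these compounds, compound 4 gives 106000 nM, the first true number in this set, so changes to the group on the saturated chain carbon bound to a carbonyl carbon now have a floor: an at least 1.8-fold lower number from compound 1 to compound 4 (0.27 log units; that floor lies within the scatter), and an at least 1.8-fold lower number from compound 2 to compound 4 (0.27 log units; that floor lies within the scatter). The closest pair differs only in isoquinolin-1-yl against isoquinolin-3-yl on the oxygen: an at least 1.8-fold lower number from compound 3 to compound 4 (0.27 log units; that floor lies within the scatter). The true size of these steps stays unreadable because the other values are limits: the limit of > 200000 nM in this assay, at which 3 of the 4 values shown sit.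

Still open, as far as these compounds go, is whether an amine or a methoxy group on the isoquinolin-1-yl ring would lower the number further. Also open, from the compounds shown here alone, is whether (isoquinolin-1-yl)sulfanyl would match (isoquinolin-1-yl)oxy.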